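A few compounds are considered here, and "the series" means these few. Any claim that something is new, unique, unknown or untested is made for them only; others in the source may bear on it.

Three measured compounds share one core and differ only in the aryl group sitting on an oxygen on an aromatic ring. Compound 1 `N[C@@H](COP(=O)(O)OCCCOC(=O)CCc1ccccc1OCc1cccc(Oc2ccccc2Cl)c1)C(=O)O` gives 0.069 in an assay on cells for activation of probable G-protein coupled receptor 34 (Mus musculus), with a stated time of 1 h; a higher number here means a larger maximal response, a lower number a smaller maximal response. Compound 2 `N[C@@H](COP(=O)(O)OCCCOC(=O)CCc1ccccc1OCc1cccc(Oc2cccc(Cl)c2)c1)C(=O)O` gives 0.53 in this assay, and compound 3 `N[C@@H](COP(=O)(O)OCCCOC(=O)CCc1ccccc1OCc1cccc(Oc2ccc(Br)cc2)c1)C(=O)O` gives 0.97, the highest of the three numbers. Both steps into compound 3 are large, a number 0.90 higher from compound 1 to compound 3 (beyond the scatter) and a number 0.44 higher from compound 2 to compound 3 (beyond the scatter), and the step a number 0.46 higher from compound 1 to compound 2 (beyond the scatter) is also beyond the scatter. Compound 4 `CC(C)(C)c1cccc(Oc2cccc(COc3ccccc3CCC(=O)OCCCOP(=O)(O)OC[C@H](N)C(=O)O)c2)c1` differs from compound 3 by 3-(tert-butyl)phenyl in place of 4-bromophenyl on an oxygen on an aromatic ring. No measured step brings in a 3-(tert-butyl)phenyl group, so the three steps show only that exchanging this aryl group moves the response strongly among these compounds. Because compound 3 already stands at 0.97, close to the full response of the reference agonist, there is little room above it, and a fall is more likely than a rise, though its size cannot be read from the data. Compound 4 is therefore expected to give 0.7, within 0.3 to 1. The expected step a number 0.27 lower from compound 3 to compound 4 (beyond the scatter) is a moderate decrease with wide uncertainty.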

Compound 4, intrinsic activity: the largest response reached, as a fraction of the reference agonist's: 0.39
For compound 4 the middle estimate is 0.31 above the measured one; the range from low to high includes it.
By their numbers in this assay, from the lowest: compound 1; then compound 4; then compound 2; then compound 3.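

In this assay, the new aryl group places compound 4 inside the range of the halogen-bearing compounds, not beyond it: the response falls on one side (a number 0.58 lower from compound 3 to compound 4 (beyond the scatter)) and rises on the other (a number 0.32 higher from compound 1 to compound 4 (beyond the scatter)). The smallest change comes when tert-butyl replaces chloro while the aryl attachment stays otherwise the same (a number 0.14 lower from compound 2 to compound 4 (beyond the scatter)), so the 3-chlorophenyl and 3-(tert-butyl)phenyl compounds lie closer to each other than either lies to the 4-bromophenyl compound 3. Nothing given here explains this order.

The step from compound 3 to compound 4 changes both the substituent and its place on the ring, so the compounds shown cannot separate those two contributions; a 3-bromophenyl or 4-(tert-butyl)phenyl group would do so. From the compounds shown here alone, how an amine or a carboxylic acid on this aryl ring would behave also remains open.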